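The compounds below may be only part of what the source reports. "The series", "measured", "known", "first", "only" and "open" are said of these compounds alone.

Measured so far in a functional assay on HT-29 cells (Homo sapiens) for cytotoxicity, read by MTT assay, with a stated time of 72 h; a lower number here means a stronger inhibitor, a higher number a weaker inhibitor:
compound 1 `CN(C)CCNc1nc(-c2ccc(NC(=O)Nc3ccccc3)cc2)nc2ccsc12` gives 620 nM
compound 2 `CCN(CC)CCCNc1nc(-c2ccc(NC(=O)Nc3ccccc3)cc2)nc2ccsc12` gives 730 nM

Compound 2 holds the higher of the two numbers, with compound 1 nearest; the step of a 1.2-fold higher number from compound 1 to compound 2 (0.07 log units; within the scatter) keeps the pair within the scatter, so no order between them is claimed. Within the data shown here, that step exchanges the amine at the end of the chain and is the only comparison the series offers.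

Compound 3 `CCN(CC)CCCNc1nc(-c2ccc(NC(=O)Nc3ccccc3Cl)cc2)nc2ccsc12` differs from compound 2 by chloro in place of hydrogen on an aromatic carbon. Among the measured compounds shown here, the change sits on the phenyl of the phenylcarbamoyl group, and no measured step touches that part of the molecule. The step from compound 1 to compound 2, at the amine end, does not bear on it, and nothing in the two measured numbers speaks for a move in either direction. Compound 3 is therefore expected to show a 1.0-fold lower number from compound 2 to compound 3 (0.02 log units; within the scatter), that is no move beyond the scatter, with a range wide enough to admit a real shift either way. Compound 3 is expected at 700 nM, between 250 nM and 2000 nM.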

Compound 3, half-maximal inhibitory concentration: 340 nM
Compound 3: middle estimate off by 2.1-fold (0.31 log units), on the high side; measured number inside the range.
By their numbers in this assay, from the lowest: compounds 3, 1 and 2 (each within the scatter of the next, the first and the last beyond it).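

In this assay, chloro in place of hydrogen on an aromatic carbon of the phenyl of the phenylcarbamoyl group gives a 2.1-fold lower number from compound 2 to compound 3 (0.33 log units; beyond the scatter), a modest step and the only one in the series that lies beyond the scatter. Among these compounds, the earlier comparison, a 1.2-fold higher number from compound 1 to compound 2 (0.07 log units; within the scatter), exchanged the amine at the end of the chain and stayed within the scatter, so this is the first indication that the number can move with a change on the phenyl, here ortho to a large group. No measured property or other finding on hand accounts for this step.

On these data alone, this rests on a single pair, so it remains open whether the lower number belongs to chloro itself or would also come with fluoro, methyl or methoxy in the same place, or with chloro elsewhere on that phenyl. As far as these compounds go, it is also open whether the same chloro change would carry over to the shorter dimethylamino chain of compound 1, since the step has been read only with the diethylamino chain of compound 2.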